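The source may report more compounds than this note shows. Statements on the series, on what has been measured and on what is new or still open speak of the compounds shown alone.

Compound 1, with structure `Cc1cc(-c2cnc(NCc3c(F)ccc4c3CCO4)c3cn[nH]c(=O)c23)n(C)n1`, is the only one of the three measured compounds that gives an actual number in an ADME assay on microsomes from liver (Homo sapiens) for metabolic stability, read by LC-MS, using NADPH, with stated times of 5 min and 30 min, tested at 1 uM; a lower number here means slower removal, a higher number faster removal of the compound: compound 1 shows 24 mL.min-1.g-1. Compound 2, `O=C(Nc1cnc(NCc2c(F)ccc3c2CCO3)n2cnnc12)c1cccnc1`, is reported only at a limit of this assay, < 3 mL.min-1.g-1, which is a limit and not a number. Compound 3, `CN(C(=O)c1ccccc1)c1cnc(NCc2c(F)ccc3c2CCO3)n2cnnc12`, is reported at the other limit of this assay, > 300 mL.min-1.g-1, again a limit rather than a number. Among the measured compounds shown here, the one step that can be read, an at least 100-fold higher number from compound 2 to compound 3 (2.00 log units; beyond the scatter), is large, but it exchanges one amide group for another on a different core and so tells nothing about the change considered here. Compound 4, `Cc1ncc(-c2cnc(NCc3c(F)ccc4c3CCO4)c3cn[nH]c(=O)c23)n1C`, differs from compound 1 by 1,2-dimethyl-1H-imidazol-5-yl in place of 1,3-dimethyl-1H-pyrazol-5-yl on an aromatic carbon. For the measured compounds named here, no measured step bears on this change, so no shift beyond the scatter is expected. Compound 4 is therefore estimated to give 24 mL.min-1.g-1 in this assay, within a range from 10 mL.min-1.g-1 to 60 mL.min-1.g-1. The step this estimate means, no change at the digits printed from compound 1 to compound 4 (within the scatter), is expected to lie within the scatter.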

Compound 4, intrinsic clearance in microsomes: 10 mL.min-1.g-1
The estimate for compound 4 lay 2.4-fold (0.38 log units) above the measured number, and the stated range covers the measured number.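

In this assay, among the compounds shown here, the exchange gives a 2.4-fold lower number from compound 1 to compound 4 (0.38 log units; beyond the scatter) and so shows that this position, on an aromatic carbon of a six-membered aromatic ring with 1 nitrogen, responds to how the atoms of the five-membered ring are joined, which the earlier compounds, with their different core, could not show. The two groups have the same count of heavy atoms, hydrogen-bond donors and hydrogen-bond acceptors, and neither carries a net charge, so these counts do not separate them. Nothing shown here accounts for the shift.

The compounds shown leave open what a phenyl ring, a pyridine ring or a ring carrying an aminomethyl group would do at this position. They also leave open whether the same exchange would shift the number on another core.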